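The source may report more compounds than this note shows. Statements on the series, on what has been measured and on what is new or still open speak of the compounds shown alone.

Measured so far in a functional assay on LOX IMVI cells (Homo sapiens) for antiproliferative activity; a lower number here means a stronger inhibitor of growth, a higher number a weaker inhibitor of growth:

- compound 1, `COc1ccc(-n2cc(-c3ccc(Cl)cc3)[nH]c2=S)cc1Cl`: 100000 nM
- compound 2, `COc1cc(-n2cc(-c3ccc(Cl)cc3)[nH]c2=O)cc(OC)c1OC`: 63100 nM
- compound 3, `COc1ccc(-n2cc(-c3ccc(OC)c(OC)c3)[nH]c2=S)cc1Cl`: see below

Compound 3 gives > 100000 nM, which is the limit of > 100000 nM in this assay, at which 1 of the 3 values shown sits, and not a number. Among the two actual numbers, compound 2 holds the lower one, and compound 1 sits only a short way from it, inside the usual scatter of this assay, so the two cannot be ordered against each other. The whole set lies at a weak level of growth inhibition.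

Compound 4, `COc1cc(-n2cc(-c3ccccc3)[nH]c2=O)cc(OC)c1OC`, is not yet measured. It differs from compound 2 by hydrogen in place of chloro on an aromatic carbon. Going by the values given here, no measured pair among the three compounds carries this same change, so there is no step of this kind to lean on, and the expectation rests on where compound 2 stands. The step of a 1.3-fold higher number from compound 2 to compound 4 (0.10 log units; within the scatter) is expected to be small, at most a modest move toward a higher number, and quite possibly none beyond the scatter. Compound 4 is estimated at 80000 nM in this assay, with a range from 30000 nM to 200000 nM, and with a real chance that only a limit is reported.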

Compound 4, concentration for 50% growth inhibition: > 100000 nM
Compound 4 was reported as a limit; the forecaster's own chance of this, stated with the estimate: 40%; at least 1.2-fold (0.09 log units) between middle value and limit.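

Going by these compounds alone, the 4-chlorophenyl to phenyl change gives the first one-place step in this assay, an at least 1.5-fold higher number from compound 2 to compound 4 (0.19 log units; that floor lies within the scatter). Because that floor lies within the scatter, the step does not establish that replacing chloro with hydrogen at this position weakens growth inhibition, though it does show that the chloro group is not needed to keep the compound from moving to a lower number in any readable way. Compound 4 carries a limit and not a number, so the step has a floor but no upper end, and its true size stays unknown because of that limit: the limit of > 100000 nM in this assay, at which 2 of the 4 values shown sit.

Still open, from the compounds shown here alone, is whether another group at this position, such as bromo, an amine or a carboxylic acid, would bring a number clearly lower than that of compound 2 at 63100 nM. Also open is whether the 4-chlorophenyl to phenyl change reads the same on the background of compound 1, where no such pair stands among the compounds shown.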